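The source may report more compounds than this note shows. Statements on the series, on what has been measured and on what is new or still open speak of the compounds shown alone.

Compound 1, with the structure `CC(=O)c1cc(-c2ccc(F)cc2)cc2cc(-c3ccccc3)[nH]c12`, is one of two compounds tested in a functional assay on HeLa cells (Homo sapiens) for cytotoxicity, read by MTT assay, with a stated time of 2 days; a lower number here means that less compound is tolerated, a higher number that more compound is tolerated; in that assay compound 1 gives 38000 nM, the lowest of the two numbers shown. Its nearest neighbour is compound 2, the structure `COc1ccc(-c2cc3cc(-c4ccc(F)cc4)cc(C(C)=O)c3[nH]2)cc1`, which in this assay gives 42800 nM. For the measured compounds named here, the single step between measured compounds is a 1.1-fold higher number from compound 1 to compound 2 (0.05 log units; within the scatter), a change of methoxy in place of hydrogen on an aromatic carbon.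

Compound 3, with the structure `CC(=O)c1cc(/C=C/c2ccc(F)cc2)cc2cc(-c3ccccc3)[nH]c12`, differs from compound 1 by 2-(4-fluorophenyl)ethenyl in place of 4-fluorophenyl on an aromatic carbon. Going by the values given here, no measured step touches the same part of the molecule: the step from compound 1 to compound 2 concerns a methoxy group elsewhere and lies within the scatter, so it offers no guidance on the direction a lengthened linker would take. With nothing pointing either way, the expectation for this assay is a step of no real size beyond the scatter, which is the meaning of no change at the digits printed from compound 1 to compound 3 (within the scatter). On that basis compound 3 is estimated to give 38000 nM in this assay, within a range of 14000 nM to 100000 nM.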

Compound 3, concentration lethal to 50% of the cells: 9260 nM
Beside the measured number, compound 3's estimate is 4.1-fold (0.61 log units) above it; the measured number lies below the stated range.
By their numbers in this assay, from the lowest: compound 3; then compounds 1 and 2 (each within the scatter of the next).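

In this assay, this position on an aromatic carbon, meta to the acetyl group, responds to the change made there: 2-(4-fluorophenyl)ethenyl in place of 4-fluorophenyl gives a 4.1-fold lower number from compound 1 to compound 3 (0.61 log units; beyond the scatter). This is the only step shown that lies beyond the scatter, whereas the methoxy change gives a 1.1-fold higher number from compound 1 to compound 2 (0.05 log units; within the scatter), which lies within it. The entering group keeps the six-membered aromatic ring and the fluorine and adds one double bond outside aromatic rings, but nothing available explains why the number falls with this change.

The compounds shown leave open whether the double bond itself or the greater length of the group goes with the lower number, a question that a saturated ethyl chain or a triple bond in the same place could address. They also leave open whether the fluorine matters on the ethenyl-linked ring, and how an amine or a carboxylic acid at this position would compare in this cell assay, or whether methoxy would behave differently on compound 3.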